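The source may report more compounds than this note shows. Statements on the series, on what has been measured and on what is new or still open speak of the compounds shown alone.

Compound 2 `Cc1cc(O)c2c(c1Cl)C(=O)C=CC2=O` gives 13500 nM in a functional assay on HeLa cells (Homo sapiens) for cytotoxicity, read by XTT assay, with a stated time of 24 h; on this read-out higher numbers stand for weaker inhibition and lower numbers for stronger inhibition. Among the three measured compounds it sits at the low end of the numbers: compound 1 `CCOc1cc(C)c(Cl)c2c1C(=O)C=CC2=O` gives 19000 nM, which lies within the scatter of compound 2, while compound 3 `CC(=O)Oc1cc(OC(C)=O)c2c(OC(C)=O)c(C)cc(Cl)c2c1OC(C)=O` gives 27900 nM, beyond the scatter of compound 2. The one single-point step among these compounds, a 1.4-fold lower number from compound 1 to compound 2 (0.15 log units; within the scatter), concerns an ethyl on an oxygen giving way to hydrogen and did not move the number beyond the scatter.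

Compound 4 `Cc1cc(O)c2c(c1F)C(=O)C=CC2=O` has not yet been measured. It differs from compound 2 in one place: fluoro in place of chloro on an aromatic carbon. Going by the values given here, no measured step exchanges one halogen for another, so nothing in the data bears directly on this change; the only measured step, a 1.4-fold lower number from compound 1 to compound 2 (0.15 log units; within the scatter), speaks for small movements. A step within the scatter is therefore expected, with no clear direction. Compound 4 is therefore expected to show a 1.0-fold higher number from compound 2 to compound 4 (0.02 log units; within the scatter). Compound 4 is estimated at 14000 nM, in the range from 6000 nM to 35000 nM.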

Compound 4, half-maximal inhibitory concentration: 10200 nM
Beside the measured number, compound 4's estimate is 1.4-fold (0.14 log units) above it; the range from low to high includes it.
By their numbers in this assay, from the lowest: compounds 4, 2, 1 and 3 (each within the scatter of the next, the first and the last beyond it).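

Going by these compounds alone, the aromatic carbon para to a hydroxy group and ortho to a methyl group is varied here for the first time, and fluoro in place of chloro gives a 1.3-fold lower number from compound 2 to compound 4 (0.12 log units; within the scatter) in this assay on this read-out. This position therefore accepts either halogen without the number moving beyond the scatter, just as the earlier change on the oxygen, a 1.4-fold lower number from compound 1 to compound 2 (0.15 log units; within the scatter), stayed within it. No measurement at hand accounts for how closely the two halogens agree.

The compounds shown carry only chloro and fluoro at this position, so it remains open whether bromo, an amine or a nitrile there would stay within the scatter. Also open, on these data alone, is what a longer chain on the oxygen, or a carboxylic acid in place of the methyl group, would do to the number.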